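Swapping a Methoxyethyl Group for an Isoxazole on Compound 2

A few compounds are considered here, and "the series" means these few. Any claim that something is new, unique, unknown or untested is made for them only; others in the source may bear on it.

Compound 1, `CCCCNc1nc(N)nc2ccn(CC=C(C)C)c12`: > 24000 nM
Compound 2, `COCCCNc1nc(N)nc2ccn(Cc3ccccn3)c12`: > 24000 nM

Both values come from an ADME assay on HEK293 cells (Homo sapiens) for cytotoxicity, read by ATP content, with a stated time of 6 h; on this read-out lower numbers stand for higher toxicity in this test and higher numbers for lower toxicity in this test. For compound 1 the value > 24000 nM is a limit of the assay, not a number. For compound 2 the value > 24000 nM is likewise a limit. Compound 2 stands at the limit of > 24000 nM in this assay, at which 2 of the 2 values shown sit. Compound 3, `CC(C)c1cc(CNc2nc(N)nc3ccn(Cc4ccccn4)c23)no1`, is not yet measured; it differs from compound 2 by 5-isopropyl-1,2-oxazol-3-yl in place of 2-methoxyethyl on a saturated chain carbon bound to a nitrogen on an aromatic ring. Among the compounds with values here, no measured pair shows a change of this kind. The step of an at least 1.2-fold lower number from compound 2 to compound 3 (0.07 log units; that floor lies within the scatter) is expected to be none beyond the scatter. Compound 3 is therefore estimated at 20000 nM in this assay, within 5000 nM to 60000 nM.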

Compound 3, half-maximal cytotoxic concentration: > 24000 nM
Compound 3 gave a limit, no number (the forecaster's own chance of this, stated with the estimate: 65%); at least 1.2-fold (0.07 log units) between middle value and limit.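

No step can be read from compound 2 to compound 3, because both give only a limit in this assay: the limit of > 24000 nM in this assay, at which 3 of the 3 values shown sit. The compounds shown leave open whether 5-isopropyl-1,2-oxazol-3-yl in place of 2-methoxyethyl changes the read-out at all.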